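A few compounds are considered here, and "the series" means these few. Any claim that something is new, unique, unknown or untested is made for them only; others in the source may bear on it.

Compound 1 `COc1cc2c(cc1OC)C(=O)/C(=C/c1cccc(Cl)c1)CC2` carries a 3-chlorophenyl group on the shared core, and in a functional assay on Jurkat cells (Homo sapiens) for antiproliferative activity, read by MTT assay (a lower number here means a stronger inhibitor, a higher number a weaker inhibitor), compound 1 gives 9000 nM. Compound 2 `COc1ccc(OC)c(/C=C2\CCc3cc(OC)c(OC)cc3C2=O)c1` gives 11000 nM in this assay, a value that stays within the scatter of compound 1. Compound 3 `COc1cc2c(cc1OC)C(=O)/C(=C/c1c(OC)cccc1OC)CC2` reaches only > 50000 nM in this assay, which is a limit rather than a number (the limit of > 50000 nM in this assay, at which 1 of the 3 values shown sits). Of the two numbers shown, compound 1 has the lower, with compound 2 closest to it. Compound 4 `COc1cc2c(cc1OC)C(=O)/C(=C/c1cc(C)cc(C)c1)CC2` has not yet been measured; it differs from compound 1 by 3,5-dimethylphenyl in place of 3-chlorophenyl on a double-bonded chain carbon bound to a double-bonded ring carbon. For the measured compounds named here, no measured pair mirrors this change, so the expected step in this assay is a 1.3-fold higher number from compound 1 to compound 4 (0.12 log units; within the scatter), small and with no direction beyond the scatter. Compound 4 is therefore estimated at 12000 nM, within a range from 4000 nM to 40000 nM.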

Compound 4, half-maximal inhibitory concentration: 4000 nM
Compound 4: middle estimate off by 3.0-fold (0.48 log units), on the high side; the range from low to high includes it.
By their numbers in this assay, from the lowest: compound 4; then compounds 1 and 2 (each within the scatter of the next). At a limit, above all of these: compound 3.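

Putting 3,5-dimethylphenyl in place of 3-chlorophenyl on a double-bonded chain carbon bound to a double-bonded ring carbon gives a 2.3-fold lower number from compound 1 to compound 4 (0.35 log units; beyond the scatter) in this assay, a modest step beyond the scatter. The chlorine of compound 1 is therefore not required for activity here, and this position accepts a ring carrying two methyl groups without any loss. Going by these compounds, whether a single methyl group, a methoxy group, an amine or a carboxylic acid at this position would keep the lower number remains open. Nothing shown here bears on why the number falls.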